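This account rests on a few compounds, and the source may have more. Where it says the series, first, only, none or still open, it means among the compounds named here.

Measured in a toxicity assay on Huh-7.5 cells (Homo sapiens) for inhibition, read by MTT assay, with a stated time of 96 h; on this read-out higher numbers stand for lower toxicity in this test and lower numbers for higher toxicity in this test:
- compound 1 `CN1CCN(Cc2ccc(NC(=O)c3ccc(OCCCl)c([N+](=O)[O-])c3)cc2C(F)(F)F)CC1` gives 9040 nM
- compound 2 `CN1CCN(Cc2ccc(NC(=O)c3ccc(OCCCCCl)c([N+](=O)[O-])c3)cc2C(F)(F)F)CC1` gives 3740 nM

Of these two compounds, compound 2 stands lowest at 3740 nM, which marks it as the more toxic of the pair. Compound 3 `CC(C)Oc1ccc(C(=O)Nc2ccc(CN3CCN(C)CC3)c(C(F)(F)F)c2)cc1[N+](=O)[O-]` differs from it at one place, with isopropyl in place of 4-chlorobutyl on an oxygen on an aromatic ring. Going by the values given here, only one measured step bears on this change, the modest 2.4-fold lower number from compound 1 to compound 2 (0.38 log units; beyond the scatter), which also altered the group on that oxygen. Among the compounds with values here, since no measured compound lacks the chlorine, this guide is indirect. A step of similar modest size is therefore expected in this assay, towards a higher number. The expected change is a 2.4-fold higher number from compound 2 to compound 3 (0.38 log units; beyond the scatter). Compound 3 is estimated at 9000 nM, within an expected range from 3500 nM to 23000 nM.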

Compound 3, half-maximal cytotoxic concentration: 3500 nM
Estimate against measurement, compound 3: 2.6-fold (0.41 log units) above, within the range that was stated.
By their numbers in this assay, from the lowest: compounds 3 and 2 (each within the scatter of the next); then compound 1.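

In this assay, isopropyl in place of 4-chlorobutyl on an oxygen on an aromatic ring gives a 1.1-fold lower number from compound 2 to compound 3 (0.03 log units; within the scatter), so these two groups cannot be told apart at this position. Isopropyl in place of 2-chloroethyl gives a 2.6-fold lower number from compound 1 to compound 3 (0.41 log units; beyond the scatter), which shows that a number of this size does not require a chlorine on the group at this oxygen and leaves compound 1 apart from the other two. No measurement given here accounts for these numbers.

Still open, from the compounds shown here alone, is how the read-out responds to an unbranched butyl chain, which would separate the loss of chlorine from the change in chain shape. Also open, going by these compounds, is how it responds to a longer chlorinated chain, an amine or a carboxylic acid on that oxygen.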